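This account rests on a few compounds, and the source may have more. Where it says the series, first, only, none or still open, it means among the compounds named here.

Measured in an ADME assay on microsomes from liver (Homo sapiens) for metabolic stability; a lower number here means slower removal, a higher number faster removal of the compound:
- Compound 1 `CCCC(Oc1ccc(-n2cc(OC)cn2)cc1)c1ccc(C(=O)NCCC(=O)O)cc1`: < 8 mL/min/kg, a limit
- Compound 2 `CCCC(Oc1ccc(-n2cc(C#N)cn2)cc1)c1ccc(C(=O)NCCC(=O)O)cc1`: < 8 mL/min/kg, a limit
- Compound 3 `CCCC(Oc1ccc(-n2cc3c(n2)CCCC3)cc1)c1ccc(C(=O)NCCC(=O)O)cc1`: 48 mL/min/kg

In this assay, for the measured compounds named here, compound 3 stands at 48 mL/min/kg, the only true number in this small set. The values of compound 1 and compound 2 are limits of the assay. Compound 4 `CCCC(Oc1ccc(-n2cc(F)cn2)cc1)c1ccc(C(=O)NCCC(=O)O)cc1` departs from compound 3 at one place: a group of 6 heavy atoms (3 carbon, 2 nitrogen, 1 fluorine; one five-membered aromatic ring with 2 hetero atoms) in place of a group of 9 heavy atoms (7 carbon, 2 nitrogen; one five-membered aromatic ring with 2 hetero atoms, one six-membered non-aromatic ring of carbon only), on an aromatic carbon. The 4-fluoro-1H-pyrazol-1-yl group enters on an aromatic carbon of a six-membered aromatic ring of carbon only, para to a large group, and the six-membered non-aromatic ring of carbon only is gone.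

Like compound 1 and compound 2, compound 4 lacks that non-aromatic ring. Two measured steps therefore bear on the change: an at least 6.0-fold higher number from compound 1 to compound 3 (0.77 log units; beyond the scatter) and an at least 6.0-fold higher number from compound 2 to compound 3 (0.77 log units; beyond the scatter). Both lie beyond the scatter, and both sizes rest on (the limit of < 8 mL/min/kg in this assay, at which 2 of the 3 values shown sit). The third comparison, a step that the two limits leave unreadable from compound 1 to compound 2, offers no guide to size.

On the strength of the two readable steps, a clear fall in this assay is expected, towards slower removal, though the fluoro group itself has not been measured. The expected change is a 6.0-fold lower number from compound 3 to compound 4 (0.78 log units; beyond the scatter). For compound 4 the estimated value is 8 mL/min/kg, with an expected range of 4 mL/min/kg to 18 mL/min/kg.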

Compound 4, clearance: 12 mL/min/kg
Compound 4: middle estimate off by 1.5-fold (0.18 log units), on the low side; measured number inside the range.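

In this assay, replacing the group with the six-membered non-aromatic ring of carbon only by 4-fluoro-1H-pyrazol-1-yl gives a 4.0-fold lower number from compound 3 to compound 4 (0.60 log units; beyond the scatter). For the compounds shown here, this is the first step at this position with a true number at both ends, so the size of this change can be read directly and not only as a bound. Against the other two compounds without that non-aromatic ring, the comparisons give only an at least 1.5-fold higher number from compound 2 to compound 4 (0.17 log units; that floor lies within the scatter) and an at least 1.5-fold higher number from compound 1 to compound 4 (0.17 log units; that floor lies within the scatter), so fluoro cannot be placed in order against cyano or methoxy, and both steps rest on a limit: the limit of < 8 mL/min/kg in this assay, at which 2 of the 4 values shown sit.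

The compounds shown do not separate the loss of the six-membered non-aromatic ring from the entry of the fluoro group, since both belong to the single change from compound 3 to compound 4. They also leave open how a methyl group or a chloro group in place of the fluoro would stand in this assay, and whether a five-membered non-aromatic ring of carbon only would behave as the six-membered one does.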